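Adding a second chloro to a biaryl benzylamine series

The compounds below may be only part of what the source reports. "The series", "measured", "known", "first", "only" and "open" are said of these compounds alone.

Measured compounds:
- compound 1, `FC(F)(F)c1ccccc1-c1nc(NCc2ccc(Cl)cc2)c2ccccc2n1`: 4800 nM
- compound 2, `FC(F)(F)c1ccccc1-c1nc(NCc2ccc(Cl)c(Cl)c2)c2ccccc2n1`: 10400 nM
- compound 3, `FC(F)(F)c1ccccc1-c1nc(NCc2ccc(-c3cccc(Cl)c3)cc2)c2ccccc2n1`: 2700 nM

In an assay on a protein complex for inhibition of ubiquitin carboxyl-terminal hydrolase 1/WD repeat-containing protein 48 (Homo sapiens), read by fluorescence (on this read-out lower numbers stand for stronger inhibition and higher numbers for weaker inhibition), compound 1 gives 4800 nM. Compound 2 differs from it by chloro in place of hydrogen on an aromatic carbon and in this assay compound 2 gives 10400 nM, a step of a 2.2-fold higher number from compound 1 to compound 2 (0.34 log units; beyond the scatter). Compound 3 differs from compound 1 by 3-chlorophenyl in place of chloro on an aromatic carbon, and compound 3 gives 2700 nM, a step of a 1.8-fold lower number from compound 1 to compound 3 (0.25 log units; within the scatter).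

Compound 4, `FC(F)(F)c1ccccc1-c1nc(NCc2ccc(-c3ccc(Cl)c(Cl)c3)cc2)c2ccccc2n1`, has not yet been measured. It differs from compound 3 by chloro in place of hydrogen on an aromatic carbon. Among the measured compounds shown here, this is the same kind of change as the one from compound 1 to compound 2, with a difference in its surroundings: in compound 2 the entering chloro stands meta to a large group, whereas in compound 4 it stands para to a large group, and the cores differ as told by 3-chlorophenyl in place of chloro on an aromatic carbon.

The earlier pair gave a 2.2-fold higher number from compound 1 to compound 2 (0.34 log units; beyond the scatter). A step of about the same size is expected here, that is roughly a 2.2-fold higher number from compound 3 to compound 4 (0.35 log units; beyond the scatter), resting only on that single earlier pair. Compound 4 is therefore estimated at 6000 nM, with a range from 2500 nM to 14000 nM.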

Compound 4, half-maximal inhibitory concentration: 2200 nM
Estimate against measurement, compound 4: 2.7-fold (0.44 log units) above; the measured number lies below the stated range.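

In this assay, the added chloro gives a 1.2-fold lower number from compound 3 to compound 4 (0.09 log units; within the scatter), and replacing the chloro on the aromatic carbon with 3,4-dichlorophenyl gives a 2.2-fold lower number from compound 1 to compound 4 (0.34 log units; beyond the scatter), a modest step. Although only the earlier chloro step lies beyond the scatter, the two chloro steps cannot be told apart, so these compounds give no firm sign that the core alters the effect of this change: the same change on two cores in this assay, a 2.2-fold higher number (0.34 log units; beyond the scatter) from compound 1 to compound 2 and a 1.2-fold lower number (0.09 log units; within the scatter) from compound 3 to compound 4, 2.7-fold (0.42 log units) apart, within the scatter of two such steps. This does not show that the change carries over unaltered, since a single pair on each core cannot establish that the step is the same on both, and it cannot separate a real dependence on the core from the scatter of the measurements.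

The compounds shown leave open whether the same small step would hold on the 3-chlorophenyl ring for a fluoro, a methoxy, a nitrile or a carboxylic acid in place of the entering chloro. They also leave open whether the result would persist on a core in which the trifluoromethyl group is replaced by, for example, a methyl group or a nitrile.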